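This account rests on a few compounds, and the source may have more. Where it says the series, first, only, none or still open, it means among the compounds named here.

Measured so far:
compound 1 `CNC(=O)c1cc(C(=O)NC2CC2)cn([C@H](C)c2ccccc2)c1=O`: 815 ug/mL
compound 2 `CNC(=O)c1cc(C(=O)NC2CC2)cn(Cc2ccc(F)cc2)c1=O`: 84 ug/mL

In a physicochemical assay for solubility, read by HPLC, in simulated intestinal fluid, with a stated time of 16 h, tested at 125 ug/mL (on this read-out lower numbers stand for lower solubility and higher numbers for higher solubility), compound 2 gives 84 ug/mL, the lowest of the two numbers; the nearest is compound 1, which in this assay gives 815 ug/mL. Going by the values given here, the only measured step, a 9.7-fold lower number from compound 1 to compound 2 (0.99 log units; beyond the scatter), swaps the group on the aromatic nitrogen and is the sole guide to how this position moves the read-out.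

Compound 3 `CNC(=O)c1cc(C(=O)NC2CC2)cn(Cc2cccc3c2CCN3)c1=O` differs from compound 2 in 2,3-dihydro-1H-indol-4-yl in place of 4-fluorophenyl on a saturated chain carbon bound to an aromatic nitrogen. Among the compounds with values here, the change sits in the same region that the one known step varied, but that step did not involve the groups exchanged here, so it bears only loosely on the present case; the expectation is therefore weakly anchored. On balance a modest upward step is expected, a 2.4-fold higher number from compound 2 to compound 3 (0.38 log units; beyond the scatter). For compound 3 the expected value in this assay is 200 ug/mL, with a range from 60 ug/mL to 600 ug/mL.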

Compound 3, solubility: 100 ug/mL
Beside the measured number, compound 3's estimate is 2.0-fold (0.30 log units) above it; the measured number falls inside the stated range.
By their numbers in this assay, from the lowest: compounds 2 and 3 (each within the scatter of the next); then compound 1.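

In this assay, 2,3-dihydro-1H-indol-4-yl in place of 4-fluorophenyl on a saturated chain carbon bound to an aromatic nitrogen gives a 1.2-fold higher number from compound 2 to compound 3 (0.08 log units; within the scatter), so compound 2 and compound 3 cannot be told apart on this read-out. Going by these compounds alone, this holds although the entering group has 1 hydrogen-bond donor and 1 hydrogen-bond acceptor and the leaving group has none, while the only step beyond the scatter at this position remains a 9.7-fold lower number from compound 1 to compound 2 (0.99 log units; beyond the scatter). Nothing on hand explains the result.

Open, on these data alone, is whether an amine or a carboxylic acid on the aromatic ring would move the read-out beyond the scatter. Also open, as far as these compounds go, is how a longer chain to the aromatic nitrogen would read against 1-phenylethyl on the same core.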